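Ether group replacement at the shared core

This account rests on a few compounds, and the source may have more. Where it says the series, first, only, none or still open, it means among the compounds named here.

In an assay for inhibition of kynurenine 3-monooxygenase (Homo sapiens), read by mass spectrometry, with a stated time of 1 h (on this read-out lower numbers stand for stronger inhibition and higher numbers for weaker inhibition), compound 3 `COCCOc1cc2oc(=O)n(CCC(=O)O)c2cc1Cl` gives 31.6 nM, the highest of the three numbers measured. Compound 1 `O=C(O)CCn1c(=O)oc2cc(OCc3ccccn3)c(Cl)cc21` gives 3.16 nM, and compound 2 `C[C@@H](Oc1cc2oc(=O)n(CCC(=O)O)c2cc1Cl)c1ccc(F)cn1` gives 2.51 nM; both sit well under compound 3. Among the compounds with values here, the single one-point step available, a 10-fold higher number from compound 1 to compound 3 (1.00 log units; beyond the scatter), shows how much was lost when the aromatic ether group was exchanged for the chain. Compound 4 `C[C@@H](Oc1cc2oc(=O)n(CCC(=O)O)c2cc1Cl)c1ncccn1` reverses that exchange: a group of 8 heavy atoms (6 carbon, 2 nitrogen; one six-membered aromatic ring with 2 hetero atoms) in place of a group of 4 heavy atoms (3 carbon, 1 oxygen; no ring), on an oxygen on an aromatic ring. Compound 4 also carries the branching methyl found in compound 2, whose value sits close to that of compound 1, so an aromatic ring at this position appears to hold potency with or without the methyl. The step is therefore expected to run opposite to the recorded loss, with compound 4 expected at a 7.9-fold lower number from compound 3 to compound 4 (0.90 log units; beyond the scatter). Compound 4 is estimated at 4 nM, within 1.5 nM to 12 nM.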

Compound 4, half-maximal inhibitory concentration: 5.01 nM
Estimate against measurement, compound 4: 1.3-fold (0.10 log units) below; low and high end bracket the measured number.
By their numbers in this assay, from the lowest: compounds 2, 1 and 4 (each within the scatter of the next); then compound 3.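

In this assay, a different aromatic ring on this oxygen, pyrimidin-2-yl on the methyl-branched carbon, also gives a lower number than the 2-methoxyethyl chain (a 6.3-fold lower number from compound 3 to compound 4 (0.80 log units; beyond the scatter)). Its exchange for 5-fluoropyridin-2-yl (a 2.0-fold higher number from compound 2 to compound 4 (0.30 log units; within the scatter)) and its difference from the unbranched pyridin-2-yl group (a 1.6-fold higher number from compound 1 to compound 4 (0.20 log units; within the scatter)) both stay within the scatter, so this read-out does not separate the three aromatic groups. No available measurement accounts for these differences. Still open, as far as these compounds go, is whether a saturated ring such as cyclohexyl, or a chain carrying an amine, on this oxygen matches the aromatic groups. The contribution of the branching methyl alone also remains open, as no pair shown differs by that group only.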